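The compounds below may be only part of what the source reports. "The series", "measured", "known", "first", "only" and "open" are said of these compounds alone.

The study covers a small set of compounds built on a shared core. Compound 1 `O=C(Nc1cccc(-n2cc(-c3ccncc3)c(-c3ccc(Cl)c(O)c3)n2)c1)Nc1cccc(C(F)(F)F)c1`, compound 2 `COc1cc(-c2nn(-c3cccc(NC(=O)Nc4cc(C(F)(F)F)cc(C(F)(F)F)c4)c3)cc2-c2ccncc2)ccc1Cl` and compound 3 `COc1cc(-c2nn(-c3cccc(NC(=O)c4cccc(C(F)(F)F)c4)c3)cc2-c2ccncc2)ccc1Cl` have been measured in a functional assay on K562 cells (Homo sapiens) for inhibition, read by sulforhodamine B assay, with a stated time of 48 h; on this read-out higher numbers stand for weaker inhibition of growth and lower numbers for stronger inhibition of growth; compound 4 `COc1cc(-c2nn(-c3cccc(NC(=O)Nc4ccc(Cl)c(Cl)c4)c3)cc2-c2ccncc2)ccc1Cl` has not. In this assay compound 2 gives 3250 nM. For compound 1 this assay reports only a limit, > 32500 nM. For compound 3 too only a limit is reported, > 50000 nM, so compound 3 stands at an edge of what the assay can read rather than at a number (the limit of > 50000 nM in this assay, at which 1 of the 3 values shown sits). Compound 4 differs from compound 3 in one place ((3,4-dichlorophenyl)amino in place of 3-(trifluoromethyl)phenyl on a carbonyl carbon). Among the measured compounds shown here, no two measured compounds differ in only one place, so any expectation rests on what the three values show: compound 2, which like compound 4 carries an amino group on its carbonyl carbon, gives a number, whereas compound 3, without it, gives only a limit. The expected step is an at least 10-fold lower number from compound 3 to compound 4 (1.00 log units; beyond the scatter), a large move towards stronger inhibition of growth, well beyond the scatter. Compound 4 is therefore estimated at 5000 nM, with a likely range from 1500 nM to 20000 nM, though a limit remains possible.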

Compound 4, concentration for total growth inhibition: > 50000 nM
Compound 4: no number, only a limit; the forecaster's own chance of this, stated with the estimate: 25%; middle value at least 10-fold (1.00 log units) from the limit.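

Compound 3 and compound 4 both stand only at a limit in this assay, so no step between them can be read: the limit of > 50000 nM in this assay, at which 2 of the 4 values shown sit.

The compounds shown leave open whether (3,4-dichlorophenyl)amino in place of 3-(trifluoromethyl)phenyl on a carbonyl carbon changes inhibition of growth at all, and in which direction.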